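Alpha-methyl branching of the acid chain in compound 1

This account rests on a few compounds, and the source may have more. Where it says the series, first, only, none or still open, it means among the compounds named here.

Working notes on the series, read in a functional assay on CHO cells for agonist activity at Free fatty acid receptor 1 (Homo sapiens); a higher number here means that more compound is needed for the effect, a lower number that less compound is needed. Compound 1, `Cc1nc(-c2ccc(C(F)(F)F)cc2)sc1CNc1ccc(CC(=O)O)cc1`, gives in this assay only a limit, < 10000 nM. Compound 1 therefore stands on an open range and not on a number, as the limit of < 10000 nM in this assay, at which 1 of the 2 values shown sits, records. For the measured compounds named here, compound 2, `O=C(O)COc1ccc(NCc2cccc(Oc3ccccc3)c2)cc1`, gives in this assay 2040 nM; no step links it to compound 1, and its value serves only as a point of comparison. Compound 3, `Cc1nc(-c2ccc(C(F)(F)F)cc2)sc1CNc1ccc(CC(C)C(=O)O)cc1`, is not yet measured in this assay. It differs from compound 1 by 1-carboxyethyl in place of carboxy on a saturated chain carbon bound to an aromatic carbon; everything else is unchanged. Going by the values given here, no measured step covers this change, so the data give no size for it. The limit of compound 1 leaves the direction open. The expected step is a step that the limit leaves unreadable from compound 1 to compound 3 in this assay, within the scatter or modestly favourable. Compound 3 is expected to give in this assay about 1500 nM, with a range from 300 nM to 8000 nM.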

Compound 3, half-maximal effective concentration: 355 nM
Estimate against measurement, compound 3: 4.2-fold (0.63 log units) above; low and high end bracket the measured number.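

The step between compound 1 and compound 3 cannot be read, because compound 1 stands on a limit and not on a number: the limit of < 10000 nM in this assay, at which 1 of the 3 values shown sits.

The compounds shown leave open both the size and the direction of the change from carboxy to 1-carboxyethyl in this assay.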